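Working notes on three measured analogues and one pending

The source may report more compounds than this note shows. Statements on the series, on what has been measured and on what is new or still open speak of the compounds shown alone.

Values in a functional assay on HeLa cells (Homo sapiens) for cytotoxicity, read by WST assay, with a stated time of 48 h; a lower number here means a stronger inhibitor, a higher number a weaker inhibitor:
compound 1 `COc1cccc([C@@H]2OC[C@H]([C@@H](O)c3ccc(OC)c(OC)c3)C[C@H]2C/C=C/c2ccc(OC)c(OC)c2)c1` — 30100 nM
compound 2 `Oc1ccccc1/C=C/C[C@H]1C[C@@H]([C@@H](O)c2ccccc2)CO[C@@H]1c1ccccc1` — 21800 nM
compound 3 `COc1ccc(/C=C/C[C@H]2C[C@@H]([C@@H](O)c3ccc(OC)c(OC)c3)CO[C@@H]2c2ccc(OC)c(OC)c2)cc1OC` — 23800 nM

Compound 2 gives the lowest of the three numbers, yet the gaps to compound 3 and to compound 1 both lie within the usual scatter, so the three read as a single level with no order among them. Compound 4 `O=[N+]([O-])c1ccc(/C=C/C[C@H]2C[C@@H]([C@@H](O)c3ccccc3)CO[C@@H]2c2ccccc2)cc1` is not yet measured. It differs from compound 2 by 4-nitrophenyl in place of 2-hydroxyphenyl on a double-bonded chain carbon bound to a double-bonded chain carbon. Going by the values given here, no step between measured compounds is available to calibrate such a change. In this assay no step beyond the scatter is expected from compound 2 to compound 4, in either direction. Compound 4 is estimated at 22000 nM, with a range from 8000 nM to 60000 nM, which means an expected step of a 1.0-fold higher number from compound 2 to compound 4 (0.00 log units; within the scatter).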

Compound 4, half-maximal inhibitory concentration: 12400 nM
For compound 4 the middle estimate is 1.8-fold (0.25 log units) above the measured one; low and high end bracket the measured number.
By their numbers in this assay, from the lowest: compounds 4, 2, 3 and 1 (each within the scatter of the next, the first and the last beyond it).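

In this assay, the exchange of 2-hydroxyphenyl for 4-nitrophenyl on a double-bonded chain carbon bound to a double-bonded chain carbon gives a 1.8-fold lower number from compound 2 to compound 4 (0.25 log units; within the scatter) as the first step readable at this position. The phenol hydroxyl of compound 2 is therefore not required to hold this level, since compound 4, which lacks it, stays within the scatter of compound 2. No supporting data bear on why this exchange is tolerated.

On these data alone, whether an amine or a carboxylic acid at this position would stay at the same level remains open. Also open, as far as these compounds go, is whether a step beyond the scatter can be reached at this position at all.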